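Methoxy added to a benzyl ring at the cytotoxicity limit

This account rests on a few compounds, and the source may have more. Where it says the series, first, only, none or still open, it means among the compounds named here.

Three compounds that share a purine-like core carrying a cyclic ether on one ring and a substituted benzylamine on the other were tested in an ADME assay on BJ cells (Homo sapiens) for cytotoxicity, read by MTT assay, with a stated time of 72 h; a higher number here means a weaker inhibitor, a lower number a stronger inhibitor. Compound 1 `COc1ccc(CNc2ncnc3c2ncn3C2CCCCO2)cc1OC` is the parent of the pair. In this assay compound 1 reaches only the limit of the assay, > 100000 nM. Compound 2 `COc1cc(CNc2ncnc3c2ncn3C2CCCCO2)cc(OC)c1OC` differs from it by methoxy in place of hydrogen on an aromatic carbon. In this assay compound 2 likewise reaches only the limit, > 100000 nM. The step that the two limits leave unreadable from compound 1 to compound 2 therefore cannot be read, since both ends sit at the same limit. Compound 3 `COc1cccc(CNc2ncnc3c2ncn3C2CCCO2)c1` carries a smaller cyclic ether, and the difference between its core and that of compound 1 is not broken down here. In this assay compound 3 also reaches only the limit, > 100000 nM.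

Compound 4 `COc1ccc(OC)c(CNc2ncnc3c2ncn3C2CCCO2)c1` has not been measured. It differs from compound 3 by methoxy in place of hydrogen on an aromatic carbon. Going by the values given here, this is the same kind of change as the one from compound 1 to compound 2, but the surroundings differ: in compound 4 the new group sits ortho to a large group and para to a methoxy group, whereas in compound 2 it sits ortho to a methoxy group, meta to a large group and meta to a methoxy group.

Among the compounds with values here, the only evidence on the measured step is the limit of > 100000 nM in this assay, at which 3 of the 3 values shown sit. Because of the limit of > 100000 nM in this assay, at which 3 of the 3 values shown sit, the step that the limit leaves unreadable from compound 3 to compound 4 is expected to be unreadable as well. Compound 4 is expected to give 150000 nM in this assay, most likely again as a limit. For compound 4 the expected range runs from 50000 nM to 500000 nM.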

Compound 4, half-maximal inhibitory concentration: > 50000 nM
Compound 4: no number, only a limit; the forecaster's own chance of this, stated with the estimate: 85%; the middle value lies beyond the limit too.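

In this assay compound 4 gives > 50000 nM, which is a limit and not a number. Compound 3 also gives only a limit, so the step from compound 3 to compound 4 cannot be read. The compounds shown leave open the concentration at which any of them would reach half-maximal inhibition, and whether methoxy in place of hydrogen on an aromatic carbon shifts it at all.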